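From 4-ethylpiperazin-1-yl to 4-methylpiperazin-1-yl in compound 2

A few compounds are considered here, and "the series" means these few. Any claim that something is new, unique, unknown or untested is made for them only; others in the source may bear on it.

In a functional assay on Raji cells (Homo sapiens) for antiproliferative activity, read by CCK-8 assay, with a stated time of 48 h (a higher number here means a weaker inhibitor, a lower number a stronger inhibitor), compound 1 (`C=CC(=O)Nc1cccc(-n2cnc3cnc(Nc4ccc(OC)cc4)nc32)c1`) gives 31200 nM as its value, and compound 3 (`C=CC(=O)Nc1cccc(-n2cnc3cnc(Nc4ccc(N5CCN(C(C)=O)C(C)C5)cc4)nc32)c1`) gives 24200 nM as its value. Compound 2 (`C=CC(=O)Nc1cccc(-n2cnc3cnc(Nc4ccc(N5CCN(CC)CC5)cc4OC)nc32)c1`) stands at the limit of > 40000 nM in this assay, at which 1 of the 3 values shown sits, with > 40000 nM as its reading, which is a limit and not a number.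

The change to compound 4 (`C=CC(=O)Nc1cccc(-n2cnc3cnc(Nc4ccc(N5CCN(C)CC5)cc4OC)nc32)c1`) is hydrogen in place of methyl on a saturated chain carbon bound to an amine nitrogen in a ring and amounts to hydrogen in place of methyl on a saturated chain carbon bound to an amine nitrogen in a ring, that is, ethyl to methyl. Among the measured compounds shown here, no measured step touches this group directly. The only one available, a 1.3-fold lower number from compound 1 to compound 3 (0.11 log units; within the scatter), replaces methoxy with 4-acetyl-3-methylpiperazin-1-yl and stays within the scatter, so it offers only weak guidance.

On that basis, no shift beyond the scatter is expected in this assay. The estimated outcome is an at least 1.0-fold lower number from compound 2 to compound 4 (0.02 log units; that floor lies within the scatter) and it remains uncertain because compound 2 has only the limit > 40000 nM as a starting point. For compound 4 the expected value is 38000 nM with an estimated range of 20000 nM to 70000 nM and a reading at the limit would be no surprise.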

Compound 4, half-maximal inhibitory concentration: 13700 nM
Estimate against measurement, compound 4: 2.8-fold (0.44 log units) above; the measured number lies below the stated range.
By their numbers in this assay, from the lowest: compounds 4, 3 and 1 (each within the scatter of the next, the first and the last beyond it). At a limit, above all of these: compound 2.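

In this assay, among the compounds shown here, the change from 4-ethylpiperazin-1-yl to 4-methylpiperazin-1-yl gives the first step that lies beyond the scatter: an at least 2.9-fold lower number from compound 2 to compound 4 (0.46 log units; beyond the scatter). For the compounds shown here, this place therefore responds to an exchange as small as hydrogen for methyl on a saturated chain carbon bound to an amine nitrogen in a ring, whereas the only earlier step, a 1.3-fold lower number from compound 1 to compound 3 (0.11 log units; within the scatter), replaced a whole group and stayed within the scatter. Compound 2 stands only at a limit, not at a number: the limit of > 40000 nM in this assay, at which 1 of the 4 values shown sits.

From the compounds shown here alone, whether the same direction holds for a free piperazine amine, with hydrogen on that ring nitrogen, or for a longer chain such as propyl there remains open. Going by these compounds, how the methoxy shared by compound 2 and compound 4 contributes to these readings also remains open.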